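Taking the Benzyl Group Off Compound 2

The source may hold more compounds than are shown below. What is called first, only, known or untested is meant among the compounds shown, and "the series" means these compounds.

Within the data shown here, in an assay on nucleic acid for binding affinity to Nucleic Acid, read by FRET, tested at 3 uM (a higher number here means that the compound stabilises the target more against heat, a lower number that the compound stabilises the target less), compound 2 `O=C(NCCN1CCCCC1)c1ccc(-c2csc3nc(-c4ccc(OCc5ccccc5)cc4)nn23)cc1` gives 2.7 degrees C, the only true number so far. Compound 1 `CCOC(=O)c1ccc(-c2csc3nc(-c4ccc(OCc5ccccc5)cc4)nn23)cc1` gives < 1 degrees C, which is a limit of the assay and not a number. Among the measured compounds shown here, the single measured step, a number at least 1.7 degrees C higher from compound 1 to compound 2 (beyond the scatter), came from placing (2-(piperidin-1-yl)ethyl)amino in place of ethoxy on a carbonyl carbon. Compound 3 `O=C(NCCN1CCCCC1)c1ccc(-c2csc3nc(-c4ccc(O)cc4)nn23)cc1` keeps that group and differs elsewhere: hydrogen in place of benzyl on an oxygen on an aromatic ring, so benzyloxy becomes hydroxy. The measured step lies at another place and offers no direct guide to the size of this change, so any forecast is loose. Starting from compound 2 at 2.7 degrees C, a modest fall is expected, since a sizeable group leaves and nothing but hydrogen enters. The expected change in this assay is a number 1.1 degrees C lower from compound 2 to compound 3 (beyond the scatter). Compound 3 is estimated at 1.6 degrees C, within a range of 0.5 degrees C to 3 degrees C.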

Compound 3, shift of the target's melting temperature: 1.8 degrees C
Compound 3: the middle estimate sits 0.20 degrees C below what was measured; measured number inside the range.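

Removing the whole benzyl group from the oxygen on the aromatic ring, so that benzyloxy becomes hydroxy, gives in this assay a number 0.90 degrees C lower from compound 2 to compound 3 (within the scatter). This step therefore cannot be told apart from repeat measurement, whereas the earlier step, at the carbonyl carbon, lay beyond the scatter. Compound 1 remains the only compound shown at the limit of the assay, and its entry is a limit and not a number: the limit of < 1 degrees C in this assay, at which 1 of the 3 values shown sits.

On this oxygen, the compounds shown carry only benzyl or hydrogen, so the effect of a methyl group, a longer chain or a chain ending in an amine stays open. Also open, from the compounds shown here alone, is how a carboxylic acid on the carbonyl carbon would compare with the (2-(piperidin-1-yl)ethyl)amino group.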